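The compounds below may be only part of what the source reports. "The series", "measured", "known", "first", "only" and "open" are said of these compounds alone.

Compound 2 `c1ccc(COc2ccc(COc3ccc(OCCOCCNC4CCCC4)cc3)cc2)cc1` is one of three compounds for which a number in a functional assay on SK-OV-3 cells (Homo sapiens) for inhibition, read by CCK-8 assay, with a stated time of 70 h (a higher number here means a weaker inhibitor, a lower number a stronger inhibitor), is known. Compound 1 `c1ccc(COc2ccc(OCCOCCNC3CCCCC3)cc2)cc1` gives 7370 nM in this assay, compound 2 gives 10000 nM, and compound 3 `O=Cc1ccc(COc2ccc(OCCOCCNC3CCCC3)cc2)cc1` gives 45000 nM. Compound 2 therefore stands second highest of the three: its nearest neighbour is compound 1, whose number lies within the scatter of it, and its furthest is compound 3. Among the measured compounds shown here, the one step measured so far between compounds differing in a single place is a 4.5-fold higher number from compound 2 to compound 3 (0.65 log units; beyond the scatter), a modest change that goes beyond the scatter.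

Compound 4 `c1ccc(COc2ccc(COc3ccc(OCCOCCNC4CCCCC4)cc3)cc2)cc1` is not yet measured. It differs from compound 2 in one place: cyclohexyl in place of cyclopentyl on an amine nitrogen. For the measured compounds named here, no measured step isolates this change. Going by the values given here, compound 1 carries the cyclohexyl group and compound 2 the cyclopentyl group, but the two differ elsewhere as well, so their values show only that a cyclohexyl compound and a cyclopentyl compound here sit within the scatter of each other. On that basis no step beyond the scatter is expected in this assay from compound 2 to compound 4, and the expected step is a 1.2-fold lower number from compound 2 to compound 4 (0.07 log units; within the scatter). Compound 4 is therefore estimated at 8500 nM in this assay, in the range 4000 nM to 18000 nM.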

Compound 4, half-maximal inhibitory concentration: 8080 nM
For compound 4 the middle estimate is 1.1-fold (0.02 log units) above the measured one; measured number inside the range.
By their numbers in this assay, from the lowest: compounds 1, 4 and 2 (each within the scatter of the next); then compound 3.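

In this assay, the change from cyclopentyl to cyclohexyl on the amine nitrogen can now be read on its own, as a 1.2-fold lower number from compound 2 to compound 4 (0.09 log units; within the scatter), so for this pair the larger ring of carbon leaves the number within the scatter. Among the compounds shown here, compound 4 also gives the first single-place reading of benzyloxy in place of hydrogen on an aromatic carbon, a 1.1-fold higher number from compound 1 to compound 4 (0.04 log units; within the scatter), and this too stays within the scatter. Of the three steps now available, only a 4.5-fold higher number from compound 2 to compound 3 (0.65 log units; beyond the scatter) goes beyond the scatter, so neither of the two new changes matches the size of the formyl change, although all of this rests on very few compounds.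

Nothing at hand explains why any of these steps has the size it has. The compounds shown leave open how the number would respond to a cyclobutyl or cycloheptyl group or an open chain such as isopropyl on the amine nitrogen, and to a nitrile or a carboxylic acid on the aromatic carbon that carries formyl in compound 3, and whether the formyl step would keep its size with cyclohexyl on that nitrogen.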